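Swapping the fluorophenyl arm for a pyrrole ring

The compounds below may be only part of what the source reports. "The series", "measured", "known", "first", "only" and "open" are said of these compounds alone.

Compound 1, `CC1=CC[C@H](C(C)(C)NC(=S)N/N=C/c2ccccc2)CC1`: 47600 nM
Compound 2, `CC1=CC[C@H](C(C)(C)NC(=S)N/N=C/c2ccc(N(C)C)cc2)CC1`: a limit of the assay, > 100000 nM
Compound 3, `CC1=CC[C@H](C(C)(C)NC(=S)N/N=C/c2ccc(F)cc2)CC1`: a limit of the assay, > 100000 nM

All three were tested in a functional assay on K562 cells (Homo sapiens) for inhibition, read by sulforhodamine B assay, with a stated time of 48 h; on this read-out higher numbers stand for weaker inhibition of growth and lower numbers for stronger inhibition of growth. Compound 1 gives 47600 nM. Compound 2 reaches only the limit of the assay, > 100000 nM. Compound 3 likewise reaches only the limit of the assay, > 100000 nM. Compound 3 therefore stands at the limit of > 100000 nM in this assay, at which 2 of the 3 values shown sit, the weak end of what this assay can report. The two steps away from the unsubstituted phenyl, an at least 2.1-fold higher number from compound 1 to compound 2 (0.32 log units; beyond the scatter) and an at least 2.1-fold higher number from compound 1 to compound 3 (0.32 log units; beyond the scatter), both moved toward weaker inhibition of growth, while a step that the two limits leave unreadable from compound 2 to compound 3 leaves no readable size.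

Compound 4, `CC1=CC[C@H](C(C)(C)NC(=S)N/N=C/c2ccc[nH]2)CC1`, carries 1H-pyrrol-2-yl in place of 4-fluorophenyl on a carbon with a double bond to nitrogen. Among the compounds with values here, no measured step changes the ring itself; every step so far only decorates the phenyl ring. The expectation for compound 4 therefore rests on compound 1 and the two substituted phenyls, and it is loose. Compound 4 is estimated at 60000 nM, with a range from 20000 nM to 100000 nM. This estimate means an at least 1.6-fold lower number from compound 3 to compound 4 (0.22 log units; that floor lies within the scatter) as the expected step, and it lands near what compound 1 gives, 47600 nM.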

Compound 4, concentration for total growth inhibition: > 100000 nM
Compound 4 gave a limit, no number; the forecaster's own chance of this, stated with the estimate: 45%; middle value at least 1.6-fold (0.22 log units) away from the limit.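

Exchanging the ring itself, and not only decorating it, gives an at least 2.1-fold higher number from compound 1 to compound 4 (0.32 log units; beyond the scatter) in this assay, so 1H-pyrrol-2-yl on the carbon with a double bond to nitrogen moves the same way as the two substituted phenyls. Compound 4 gives only a limit of the assay, so the step from compound 3 to compound 4 cannot be read, just as the earlier step between the two substituted phenyls cannot. Of the arms shown, only the plain phenyl of compound 1 gives a number, and the other three all end at the same boundary: the limit of > 100000 nM in this assay, at which 3 of the 4 values shown sit.

Going by these compounds, whether any arm at this place can improve on compound 1 remains open. A furan or pyridine ring here, or a carboxylic acid on the phenyl ring, would show whether growth inhibition can be regained.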